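Swapping a bromophenyl arm for a benzofuranyl one

The source may hold more compounds than are shown below. What is called first, only, known or untested is meant among the compounds shown, and "the series" means these compounds.

Compounds measured so far:
compound 1 `C/C(=N\Nc1nc(-c2ccc(Br)cc2)cs1)c1cc2ccccc2o1`: 32700 nM
compound 2 `COc1ccc(-c2csc(N/N=C(\C)c3cc4ccccc4o3)n2)cc1`: 18700 nM

In a functional assay on HeLa cells (Homo sapiens) for antiproliferative activity (on this read-out lower numbers stand for stronger inhibition and higher numbers for weaker inhibition), compound 1 gives 32700 nM. Within the data shown here, its only neighbour is compound 2, and the step of a 1.7-fold lower number from compound 1 to compound 2 (0.24 log units; within the scatter) did not leave the scatter. Compound 3 `C/C(=N\Nc1nc(-c2cc3ccccc3o2)cs1)c1cc2ccccc2o1` differs from compound 1 by 1-benzofuran-2-yl in place of 4-bromophenyl on an aromatic carbon. Among the measured compounds shown here, the sole step that touches the same place, from compound 1 to compound 2, was within the scatter, and no measured pair shows the entering benzofuranyl group at all. For compound 3 no change beyond the scatter is therefore expected, the estimated step being a 1.2-fold lower number from compound 1 to compound 3 (0.07 log units; within the scatter). Compound 3 is estimated at 28000 nM, within 9000 nM to 90000 nM.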

Compound 3, half-maximal inhibitory concentration: 24100 nM
Compound 3: the middle estimate sits 1.2-fold (0.07 log units) above what was measured; low and high end bracket the measured number.
By their numbers in this assay, from the lowest: compounds 2, 3 and 1 (each within the scatter of the next).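

In this assay, 1-benzofuran-2-yl in place of 4-bromophenyl gives a 1.4-fold lower number from compound 1 to compound 3 (0.13 log units; within the scatter), and the same group in place of 4-methoxyphenyl gives a 1.3-fold higher number from compound 2 to compound 3 (0.11 log units; within the scatter). At this aromatic carbon, next to the ring nitrogen, a group with a second aromatic ring and more heavy atoms therefore moves the number no further than the scatter from either phenyl compound. No measurement is available that bears on this result.

As far as these compounds go, whether an amine or a carboxylic acid at this carbon would shift the number beyond the scatter remains open. So does the effect of replacing the benzofuranyl group that all three compounds keep elsewhere on the core.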